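Dichlorophenyl Analogue and Expected Cytotoxicity

The source may hold more compounds than are shown below. What is called first, only, known or untested is meant among the compounds shown, and "the series" means these compounds.

Three measured compounds share one core and differ only in the chlorophenyl group on a saturated ring carbon. Compound 1 `Clc1ccc([C@@H]2C[C@@H]3Cc4ccc5ccccc5c4N2O3)cc1` carries a 4-chlorophenyl; in an ADME assay on THP-1 cells (Homo sapiens) for cytotoxicity, read by MTT assay, with a stated time of 72 h (on this read-out lower numbers stand for higher toxicity in this test and higher numbers for lower toxicity in this test), compound 1 gives > 300000 nM, which is a limit of the assay rather than a number. Compound 2 `Clc1cccc([C@@H]2C[C@@H]3Cc4ccc5ccccc5c4N2O3)c1` carries a 3-chlorophenyl, and in this assay compound 2 gives > 300000 nM, again a limit. Compound 3 `Clc1ccccc1[C@@H]1C[C@@H]2Cc3ccc4ccccc4c3N1O2` carries a 2-chlorophenyl, and in this assay compound 3 gives > 300000 nM, also a limit. Compound 2 thus stands at the limit, as do the other two. The steps a step that the two limits leave unreadable from compound 1 to compound 2, a step that the two limits leave unreadable from compound 1 to compound 3 and a step that the two limits leave unreadable from compound 2 to compound 3 cannot be sized because of the limit of > 300000 nM in this assay, at which 3 of the 3 values shown sit. Compound 4 `Clc1ccc([C@@H]2C[C@@H]3Cc4ccc5ccccc5c4N2O3)c(Cl)c1` has not been measured; it differs from compound 2 by 2,4-dichlorophenyl in place of 3-chlorophenyl on a saturated ring carbon. Every measured change to the chlorophenyl left the value at the limit, and the expected step is a number no higher from compound 2 to compound 4 (the limit leaves the size open), none beyond the scatter. Compound 4 is therefore expected to give about 300000 nM in this assay, with a range from 100000 nM to 1000000 nM.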

Compound 4, half-maximal cytotoxic concentration: > 250000 nM
Compound 4 was reported as a limit (the forecaster's own chance of this, stated with the estimate: 80%); the middle value is on the limit's open side.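

In this assay compound 4 gives > 250000 nM, which is a limit and not a number. Its steps to compound 1, compound 2 and compound 3 cannot be read. The compounds shown leave open what half-maximal cytotoxic concentration any of the four actually has, and whether the second chloro of compound 4 changes it.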